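This account rests on a few compounds, and the source may have more. Where it says the series, first, only, none or still open, it means among the compounds named here.

Compound 1 `CO/N=C(\C)c1ccc(Sc2cc(F)cc(C3CCOCC3)c2)cc1` is the reference point of this small set. Among the compounds with values here, in a functional assay (blood) for inhibition, with Homo sapiens as the target (a higher number here means a weaker inhibitor, a lower number a stronger inhibitor), compound 1 gives 110 nM, the lowest of the three numbers, yet no other compound sits beyond the scatter from it. Compound 2 `CO/N=C(\C)c1ccc(Sc2cc(F)cc([C@@]3(OC)CCO[C@@H](C)C3)c2)cc1` gives 140 nM in this assay, and the step of a 1.3-fold higher number from compound 1 to compound 2 (0.10 log units; within the scatter) is too small to rank the pair. Compound 3 `CO[C@]1(c2cnc(S(=O)(=O)c3ccc(/C(C)=N/OCC#N)cc3)s2)CCO[C@@H](C)C1` gives 140 nM in this assay; it differs from compound 1 in more than one place, so only the two values themselves can be set side by side, and they lie within the scatter.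

The step from compound 1 to compound 4 `C/C(=N\OC(=O)N(C)C)c1ccc(Sc2cc(F)cc(C3CCOCC3)c2)cc1` is the change (dimethylcarbamoyl in place of methyl on an oxygen). Cut one bond further out, it reads methoxy to (dimethylcarbamoyl)oxy. Within the data shown here, no measured step in the set touches this oxygen: the only measured single-site step, compound 1 to compound 2, sits on an aromatic carbon and was within the scatter. There is therefore no basis from the measured compounds for expecting a large move in this assay in either direction, and the estimate must carry a wide range.

Compound 4 is expected to give 200 nM in this assay, within 60 nM to 700 nM, which corresponds to an expected step of a 1.8-fold higher number from compound 1 to compound 4 (0.26 log units; within the scatter).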

Compound 4, half-maximal inhibitory concentration: 2610 nM
Compound 4: middle estimate off by 13-fold (1.12 log units), on the low side; the measured number lies above the stated range.
By their numbers in this assay, from the lowest: compounds 1, 2 and 3 (each within the scatter of the next); then compound 4.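

Within the data shown here, the oxygen on the double-bonded nitrogen is a sensitive site in this assay: dimethylcarbamoyl in place of methyl there gives a 24-fold higher number from compound 1 to compound 4 (1.38 log units; beyond the scatter) and is the only step beyond the scatter, while the change on an aromatic carbon, a 1.3-fold higher number from compound 1 to compound 2 (0.10 log units; within the scatter), stayed within it. The group on this oxygen therefore cannot be exchanged freely, as the entering group, with 5 heavy atoms against 1 and a hydrogen-bond acceptor that methyl lacks, goes with a much weaker inhibitor in this single pair. That pair does not separate the heavy-atom count from the acceptor, and no measurement among the data shown explains the loss.

Ethyl or a longer alkyl chain on this oxygen would probe a larger group without a carbonyl, whereas acetyl or methylcarbamoyl would keep the carbonyl with fewer heavy atoms than dimethylcarbamoyl. On these data alone, whether dimethylcarbamoyl would cost as much on the core of compound 2, which carries the 4-methoxy-2-methyloxan-4-yl group, also remains open.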